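Replacing 3-ethylphenyl with 4-chlorophenyl on the shared core

A few compounds are considered here, and "the series" means these few. Any claim that something is new, unique, unknown or untested is made for them only; others in the source may bear on it.

Among the measured compounds shown here, in a functional assay on L1210 cells (Mus musculus) for inhibition (on this read-out lower numbers stand for stronger inhibition and higher numbers for weaker inhibition), compound 1 `C#CCN(Cc1ccc2nc(C)nc(O)c2c1)c1cccc(CC)c1` gives 5000 nM, the only actual number in the set. Compound 2 `C#CCN(Cc1ccc2nc(C)nc(O)c2c1)c1cccc(C(C)O)c1` reads > 49000 nM, which is a limit. Compound 3 `C#CCN(Cc1ccc2nc(C)nc(O)c2c1)c1cccc(C#C)c1` reads > 2400 nM, which is also a limit.

Compound 4 `C#CCN(Cc1ccc2nc(C)nc(O)c2c1)c1ccc(Cl)cc1` differs from compound 1 as follows: 4-chlorophenyl in place of 3-ethylphenyl on an amine nitrogen. In short, 4-chlorophenyl stands in place of 3-ethylphenyl on an amine nitrogen.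

For the measured compounds named here, only one measured step has a readable size: an at least 9.8-fold higher number from compound 1 to compound 2 (0.99 log units; beyond the scatter). It shows that a change within the ethyl group can matter, but it involves a hydroxy group and no chlorine. The other two steps, a step that the limit leaves unreadable from compound 1 to compound 3 and a step that the two limits leave unreadable from compound 2 to compound 3, give no usable size. Going by the values given here, no measured step therefore sets a direction for this exchange, and no shift beyond the scatter is expected in this assay. The estimated step is a 1.2-fold higher number from compound 1 to compound 4 (0.08 log units; within the scatter), with wide uncertainty. Compound 4 is expected at 6000 nM, with an estimated range of 1500 nM to 25000 nM.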

Compound 4, half-maximal inhibitory concentration: > 4000 nM
Compound 4: only a limit was reported; the forecaster's own chance of this, stated with the estimate: 35%; the middle value lies beyond the limit too.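

Compound 4 is reported only as a limit in this assay, so neither its step from compound 1 nor its step from compound 3 can be read: the limit of > 4000 nM in this assay, at which 1 of the 4 values shown sits.

The compounds shown leave open whether 4-chlorophenyl in place of 3-ethylphenyl on an amine nitrogen shifts inhibition in this assay, and by how much.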